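A few compounds are considered here, and "the series" means these few. Any claim that something is new, unique, unknown or untested is made for them only; others in the source may bear on it.

Measured compounds in a physicochemical assay for lipophilicity, read by HPLC, at pH 7.4; a higher number here means a more lipophilic compound, a lower number a more polar compound:
compound 1 `CCOC(=O)C1=C(C)N/C(=C/c2cc(C)n(-c3ccc(OC)cc3)c2C)C1=O` gives 3;
compound 2 `CCOC(=O)C1=C(C)N/C(=C/c2cc(C)n(-c3ccc([S+](C)[O-])cc3)c2C)C1=O` gives "not determined" (no result reported).

Compound 2 therefore stands nowhere on the scale of this assay: no number exists for it, and the only measured point in the set is compound 1, which gives 3 in this assay. Compound 3 `CCOC(=O)C1=C(C)N/C(=C/c2cc(C)n(-c3ccc(CN4CCCCC4)cc3)c2C)C1=O` differs from compound 2 in a single place: a group of 7 heavy atoms (6 carbon, 1 nitrogen; one six-membered non-aromatic ring with 1 hetero atom) in place of a group of 3 heavy atoms (1 carbon, 1 oxygen, 1 sulfur; no ring), on an aromatic carbon. No number is known for compound 2, and no two measured compounds differ from each other in just one place: the step from compound 2 to compound 3 cannot be sized from the data, and no direction can be read from the numbers shown; any expectation has to lean on compound 1 alone, which sits at 3 in this assay, and on the change in structure. On that basis, compound 3 is expected to give 2.5 in this assay, with four of five repeated measurements expected to fall between 1.8 and 3.2.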

Compound 3, distribution coefficient: 8.5
The estimate for compound 3 lay 6.00 log units below the measured number, outside the stated range (above it).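

In this assay, putting (piperidin-1-yl)methyl in place of methoxy on an aromatic carbon, para to a large group, gives a number 5.50 log units higher from compound 1 to compound 3 (beyond the scatter), a large step that lies beyond the scatter. Going by these compounds alone, this is the first sign that the read-out can move strongly with a change at this place: until now the set held a single number, from compound 1, and nothing to compare it with. Compound 2 has no number, so its step to compound 3 cannot be read, and no measurement shown here accounts for the size of the step from methoxy to (piperidin-1-yl)methyl.

This rests on one pair of compounds, so the compounds shown do not tell whether the step follows the whole (piperidin-1-yl)methyl group or only a part of it; a cyclohexylmethyl group, with carbon in place of the ring nitrogen, or a morpholin-4-ylmethyl group, with an added ring oxygen, would separate those parts. As far as these compounds go, how a much smaller amine such as dimethylaminomethyl or a carboxylic acid at the same place would read also remains open.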